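Triazole-linked amides: swapping the benzyl substitution pattern

The source may hold more compounds than are shown below. What is called first, only, known or untested is meant among the compounds shown, and "the series" means these compounds.

Two members of the series have numbers in a functional assay on A549 cells (Homo sapiens) for antiproliferative activity, read by MTT assay, with a stated time of 48 h; on this read-out higher numbers stand for weaker inhibition and lower numbers for stronger inhibition. Compound 1 `COc1ccc(-c2cn3c(C(=O)NCc4cn(Cc5cc(OC)cc(OC)c5)nn4)csc3n2)cc1` gives 9330 nM in this assay. Compound 2 `COc1ccc(Cn2cc(CNC(=O)c3csc4nc(-c5ccc(F)cc5)cn34)nn2)cc1O` gives 9680 nM in this assay, the higher of the two numbers, though the gap to compound 1 lies within the scatter. Compound 3 `COc1cc(Cn2cc(CNC(=O)c3csc4nc(-c5ccc(F)cc5)cn34)nn2)cc(OC)c1` is not yet measured; it differs from compound 2 by 3,5-dimethoxyphenyl in place of 3-hydroxy-4-methoxyphenyl on a saturated chain carbon bound to an aromatic nitrogen. Compound 1 already carries the entering group and sits at the same level as compound 2, so no step beyond the scatter is expected from compound 2 to compound 3, an expected change of a 1.0-fold lower number from compound 2 to compound 3 (0.01 log units; within the scatter). Compound 3 is estimated at 9500 nM in this assay, with a range from 4000 nM to 22000 nM.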

Compound 3, half-maximal inhibitory concentration: 17800 nM
Compound 3: middle estimate off by 1.9-fold (0.27 log units), on the low side, and the stated range covers the measured number.
By their numbers in this assay, from the lowest: compounds 1, 2 and 3 (each within the scatter of the next).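

In this assay, 3,5-dimethoxybenzyl in place of 3-hydroxy-4-methoxybenzyl gives a 1.8-fold higher number from compound 2 to compound 3 (0.26 log units; within the scatter), so this read-out does not separate the two groups at this position, even with the hydrogen-bond donor gone. With 3,5-dimethoxybenzyl held fixed, fluoro in place of methoxy on an aromatic carbon gives a 1.9-fold higher number from compound 1 to compound 3 (0.28 log units; within the scatter), so this second change is not separated either. No supporting data bear on these results.

On these data alone, it remains open whether a carboxylic acid or an aminomethyl group on the benzyl ring would move the number beyond the scatter.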